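Moving the nitrile around the pyridine ring

A few compounds are considered here, and "the series" means these few. Any claim that something is new, unique, unknown or untested is made for them only; others in the source may bear on it.

Compound 1 `Cc1csc(-c2nc(N)c3cc(Cc4ccccc4)sc3n2)n1` in a functional assay on CHO-K1 cells for antagonist activity at adenosine receptor A1 (Homo sapiens), read by a beta-galactosidase reporter and cAMP accumulation, with stated times of 15 min and 6 h (on this read-out lower numbers stand for stronger inhibition and higher numbers for weaker inhibition), gives 1490 nM.
Compound 2 `Nc1nc(-c2ccccc2)nc2sc(Cc3ccccc3)cc12` gives 151 nM.
Compound 3 `N#Cc1cccc(-c2nc(N)c3cc(Cc4ccccc4)sc3n2)n1` gives only a limit of the assay, > 1000 nM.

Compound 3 therefore stands at the limit of > 1000 nM in this assay, at which 1 of the 3 values shown sits: its number is not known, and an at least 6.6-fold higher number from compound 2 to compound 3 (0.82 log units; beyond the scatter) tells only that it is weaker than compound 2. Compound 4 `N#Cc1cncc(-c2nc(N)c3cc(Cc4ccccc4)sc3n2)c1` differs from it by 5-cyanopyridin-3-yl in place of 6-cyanopyridin-2-yl on an aromatic carbon. Among the compounds with values here, no measured step moves a substituent around this ring; the steps that bear on the aryl group at all are a 9.9-fold lower number from compound 1 to compound 2 (0.99 log units; beyond the scatter) and an at least 6.6-fold higher number from compound 2 to compound 3 (0.82 log units; beyond the scatter), each swapping the whole group. The change is expected to give a step that the limit leaves unreadable from compound 3 to compound 4, with compound 4 probably again near or beyond the limit. Compound 4 is estimated at 2000 nM, between 400 nM and 10000 nM.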

Compound 4, inhibition constant: 1160 nM
For compound 4 the middle estimate is 1.7-fold (0.24 log units) above the measured one, within the range that was stated.
By their numbers in this assay, from the lowest: compound 2; then compounds 4 and 1 (each within the scatter of the next).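

Compound 3 holds only a limit of the assay, so the effect of moving the nitrile around the pyridine ring cannot be read: the limit of > 1000 nM in this assay, at which 1 of the 4 values shown sits.

Within the data shown here, compound 4 gives the first readable number for a cyanopyridine group at this position, on an aromatic carbon between two ring nitrogen atoms. Against phenyl, 5-cyanopyridin-3-yl gives a 7.7-fold higher number from compound 2 to compound 4 (0.89 log units; beyond the scatter), while against 4-methyl-1,3-thiazol-2-yl it gives a 1.3-fold lower number from compound 1 to compound 4 (0.11 log units; within the scatter), so the two groups stand level.

Still open, going by these compounds, is where compound 3 truly lies. Also open, on these data alone, is whether a plain pyridine, or an amine or carboxylic acid in place of the nitrile, would come closer to phenyl.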